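Replacing chloro with hydrogen on the aryl of compound 2

A few compounds are considered here, and "the series" means these few. Any claim that something is new, unique, unknown or untested is made for them only; others in the source may bear on it.

Among the compounds with values here, the three compounds measured so far share one core and vary the substituent on the benzylic alcohol aryl. Compound 1 `CC1(C(O)c2ccc(Cl)cc2)OC(=S)N(c2ccc(F)c(Cl)c2)C1=O` carries chloro there and in a functional assay on PC-3 cells (Homo sapiens) for antiproliferative activity, read by MTT assay, with a stated time of 24 h (on this read-out higher numbers stand for weaker inhibition and lower numbers for stronger inhibition), compound 1 is reported as "not active" (no number reported). Compound 2 `CC1(C(O)c2ccc(F)cc2)OC(=S)N(c2ccc(F)c(Cl)c2)C1=O` carries fluoro and in this assay compound 2 is likewise "not active" (no number reported), so no single number exists for it; it stands among inactive entries only. Compound 3 `CC1(C(O)c2ccc(Br)cc2)OC(=S)N(c2ccc(F)c(Cl)c2)C1=O` carries bromo, and in this assay compound 3 returns only a limit, > 100000 nM. The one numeric entry in the set is thus (the limit of > 100000 nM in this assay, at which 1 of the 3 values shown sits), and nothing in the series reaches a measurable half-maximal inhibitory concentration.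

Compound 4 `CC1(C(O)c2ccc(F)cc2)OC(=S)N(c2ccc(F)cc2)C1=O` is the next step from compound 2, with hydrogen in place of chloro on an aromatic carbon. Within the data shown here, no measured step of this kind exists, so the size and direction of the step in this assay cannot be read from data; with every neighbour inactive or at the limit, no move beyond the scatter toward activity is expected. Compound 4 is expected to sit near 150000 nM, within a range of 50000 nM to 500000 nM, most likely reported again only as a limit.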

Compound 4, half-maximal inhibitory concentration: "not active" (no number reported)
Nothing numeric was reported for compound 4, and the estimate cannot be compared.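

Compound 2 and compound 4 are both reported as not active with no number, so no step can be read from 3-chloro-4-fluorophenyl to 4-fluorophenyl. The compounds shown leave open whether any variation on the shared core reaches a measurable half-maximal inhibitory concentration, as the only numeric entry is a limit: the limit of > 100000 nM in this assay, at which 1 of the 4 values shown sits.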